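A few compounds are considered here, and "the series" means these few. Any claim that something is new, unique, unknown or untested is made for them only; others in the source may bear on it.

Measured so far:
compound 1 `Cc1cc(Br)ccc1NC(=O)COc1ccc2cc(/C=C3/SC(=O)NC3=O)ccc2c1` gives 550 nM in an assay on isolated protein for inhibition of histone deacetylase 4 (Homo sapiens), with a stated time of 1 h; a lower number here means a stronger inhibitor, a higher number a weaker inhibitor;
compound 2 `Cc1cccc(NC(=O)COc2ccc3cc(/C=C4/SC(=O)NC4=O)ccc3c2)n1` gives 1100 nM in this assay.

Compound 2 holds the higher of the two numbers, but the gap to compound 1, a 2.0-fold higher number from compound 1 to compound 2 (0.30 log units; within the scatter), lies within the scatter. Compound 3 `O=C(COc1ccc2cc(/C=C3/SC(=O)NC3=O)ccc2c1)Nc1ccc(Br)cc1` differs from compound 2 by 4-bromophenyl in place of 6-methylpyridin-2-yl on an amide-type nitrogen. For the measured compounds named here, the only step that bears on it is the one from compound 1 to compound 2, which removed the 4-bromo-2-methylphenyl group and stayed within the scatter; compound 3 brings a bromophenyl group back. Compound 3 is therefore expected to land near compound 1, a step of a 1.7-fold lower number from compound 2 to compound 3 (0.23 log units; within the scatter) that does not clearly exceed the scatter. The estimate for compound 3 is 650 nM, within 250 nM to 1700 nM.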

Compound 3, half-maximal inhibitory concentration: 2900 nM
Compound 3: middle estimate off by 4.5-fold (0.65 log units), on the low side; measured number outside the range, above it.
By their numbers in this assay, from the lowest: compounds 1 and 2 (each within the scatter of the next); then compound 3.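

On the amide-type nitrogen, the 4-bromophenyl group alone does not hold the level of compound 1: hydrogen in place of methyl on an aromatic carbon gives a 5.3-fold higher number from compound 1 to compound 3 (0.72 log units; beyond the scatter) in this assay. 4-Bromophenyl in place of 6-methylpyridin-2-yl gives a 2.6-fold higher number from compound 2 to compound 3 (0.42 log units; beyond the scatter), which makes compound 3 the weakest of the three. No measurement at hand accounts for either step.

The compounds shown leave open whether the methyl keeps its effect without the bromine, and how a methoxy group or a carboxylic acid on this ring would compare.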